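The source may hold more compounds than are shown below. What is called first, only, known or untested is meant among the compounds shown, and "the series" means these compounds.

Measured compounds in a functional assay on CHO cells with adenosine receptor A1 (Homo sapiens) as the target, read by cAMP accumulation and immunoassay, with a stated time of 6 min, tested at 1 uM; a higher number here means a weaker effect of the compound at the concentration tested, a lower number a stronger effect:
compound 1 `Nc1scc(CN2CCN(c3ccc(Cl)cc3F)CC2)c1C(=O)c1ccc(Cl)cc1`: -57%
compound 2 `Nc1scc(CN2CCN(c3ccc(Cl)c(C(F)(F)F)c3)CC2)c1C(=O)c1ccc(Cl)cc1`: -47%
compound 3 `Nc1scc(CN2CCN(c3ccc(C(F)(F)F)cc3)CC2)c1C(=O)c1cccc(C(F)(F)F)c1`: -27%

Compound 2 stands second highest of the three numbers. Compound 1 lies within the scatter of it, compound 3 higher and beyond the scatter. Compound 4 `Nc1scc(CN2CCN(c3cc(F)cc(F)c3)CC2)c1C(=O)c1ccc(Cl)cc1` is not yet measured in this assay. Its change from compound 2: 3,5-difluorophenyl in place of 4-chloro-3-(trifluoromethyl)phenyl on an amine nitrogen in a ring. Among the compounds with values here, the one measured step that bears on it, an exchange of the aryl group on the same ring nitrogen, is a number 10 percentage points higher from compound 1 to compound 2 (within the scatter). Compound 3 differs from compound 2 in two places, so it only shows that the number can rise beyond the scatter. One aryl exchange gave nothing beyond the scatter, so none is expected here. The expected step is a number 2 percentage points higher from compound 2 to compound 4 (within the scatter). Compound 4 is estimated at -45%, within -65% to -25%.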

Compound 4, a percentage reported as activity, at one concentration (the size of the read-out at that concentration, not a potency): -66%
Beside the measured number, compound 4's estimate is 21 percentage points above it; the measured number lies below the stated range.
By their numbers in this assay, from the lowest: compounds 4, 1 and 2 (each within the scatter of the next, the first and the last beyond it); then compound 3.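

In this assay an exchange of the aryl group on this ring nitrogen now gives a step beyond the scatter: a number 19 percentage points lower from compound 2 to compound 4 (beyond the scatter) when 3,5-difluorophenyl replaces 4-chloro-3-(trifluoromethyl)phenyl. The same group in place of 4-chloro-2-fluorophenyl gives a number 9 percentage points lower from compound 1 to compound 4 (within the scatter) and so the outcome of an exchange here depends on which aryl group leaves. No measurement at hand accounts for this difference.

Still open, from the compounds shown here alone, is whether an aryl group carrying a nitrile or an amine on this ring nitrogen would give a number near that of compound 4. The same holds for a saturated cyclohexyl group there.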